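A few compounds are considered here, and "the series" means these few. Any claim that something is new, unique, unknown or untested is made for them only; others in the source may bear on it.

Compound 3 `CC(=O)OC1(C(=O)Nc2ccc([N+](=O)[O-])cc2)CCCCC1` gives 517 nM in a functional assay on NFS-60 cells (Mus musculus) for inhibition, read by MTT assay, with a stated time of 72 h; a higher number here means a weaker inhibitor, a lower number a stronger inhibitor. Of the three compounds measured, it stands second highest. Compound 1 `O=C(OC1(C(=O)Nc2ccc([N+](=O)[O-])cc2)CCCCC1)c1ccccc1` gives 766 nM, and the step of a 1.5-fold lower number from compound 1 to compound 3 (0.17 log units; within the scatter) lies within the scatter. Compound 2 `O=COC1(C(=O)Nc2ccc([N+](=O)[O-])cc2)CCCCC1` gives 33.8 nM, so that a 15-fold higher number from compound 2 to compound 3 (1.18 log units; beyond the scatter) is a large step. Compound 4 `O=C(OC1(C(=O)Nc2ccc([N+](=O)[O-])cc2)CCCCC1)C(O)c1ccccc1` differs from compound 3 in one place: hydroxy(phenyl)methyl in place of methyl on a carbonyl carbon. The measured steps that bear on this change are those at the same carbonyl carbon. There, a 1.5-fold lower number from compound 1 to compound 3 (0.17 log units; within the scatter) was within the scatter, whereas a 23-fold lower number from compound 1 to compound 2 (1.36 log units; beyond the scatter) and a 15-fold higher number from compound 2 to compound 3 (1.18 log units; beyond the scatter) were both large, so among these three compounds only the hydrogen gives a low number. As compound 1, which carries a phenyl ring at this place, gives 766 nM, close to compound 3, the entering group in compound 4 is expected to behave like the larger groups, and no step beyond the scatter is expected, namely a 1.3-fold higher number from compound 3 to compound 4 (0.10 log units; within the scatter). Compound 4 is therefore estimated at 650 nM, with a range from 200 nM to 2500 nM.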

Compound 4, half-maximal inhibitory concentration: 7.8 nM
For compound 4 the middle estimate is 83-fold (1.92 log units) above the measured one; measured number below the stated range.
By their numbers in this assay, from the lowest: compound 4; then compound 2; then compounds 3 and 1 (each within the scatter of the next).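

At this carbonyl carbon in this assay, a larger group does not by itself go with a higher number: hydroxy(phenyl)methyl in place of methyl gives a large drop (a 66-fold lower number from compound 3 to compound 4 (1.82 log units; beyond the scatter)). Hydrogen also no longer gives the lowest number at this place, as the step from it to hydroxy(phenyl)methyl is modest but beyond the scatter (a 4.3-fold lower number from compound 2 to compound 4 (0.64 log units; beyond the scatter)). An aromatic ring alone does not account for the low number, since the phenyl group directly on the carbonyl carbon stands far higher (a 98-fold lower number from compound 1 to compound 4 (1.99 log units; beyond the scatter)).

The compounds shown leave open whether the hydroxy group or the added carbon carries this gain, which a plain benzyl group or an amine in place of the hydroxy would separate. Nothing measured here explains the step.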